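The compounds below may be only part of what the source reports. "The series", "measured", "known", "first", "only" and "open" are said of these compounds alone.

Compound 3 `CCn1c(-c2cnc(C)nc2)nc2c(N[C@H]3CCN(C(=O)C4CCC4)C3)ncnc21` and compound 1 `CCn1c(-c2cnc(C)nc2)nc2c(N[C@H]3CCN(C(=O)[C@H]4C[C@@H](OC)C4)C3)ncnc21` are a measured pair. In a physicochemical assay for lipophilicity, read by HPLC (on this read-out lower numbers stand for lower lipophilicity and higher numbers for higher lipophilicity), compound 3 gives 1.2, and compound 1 gives 0.9. The change between them is methoxy in place of hydrogen on a saturated ring carbon, and it made a step of a number 0.30 log units lower from compound 3 to compound 1 (within the scatter).

Compound 2 `CCn1c(-c2cnc(C)nc2)nc2c(O[C@H]3CCN(C(=O)C4CCC4)C3)ncnc21` shares this pattern on a different core; the difference between the two cores is not broken down here. In this assay compound 2 gives 1.3, which lies within the scatter of compound 3 and is separated from compound 1 by a gap beyond it.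

Compound 4 `CCn1c(-c2cnc(C)nc2)nc2c(O[C@H]3CCN(C(=O)[C@H]4C[C@@H](OC)C4)C3)ncnc21` has not yet been measured. It differs from compound 2 by methoxy in place of hydrogen on a saturated ring carbon, the same change that was made from compound 3 to compound 1. For the measured compounds named here, for compound 4 the step from compound 2 is expected to be a number 0.30 log units lower from compound 2 to compound 4 (within the scatter), resting on the step of a number 0.30 log units lower from compound 3 to compound 1 (within the scatter) seen on the other core, with the caution that only one such pair is known. Compound 4 is therefore estimated to give 1 in this assay, expected to fall between 0.7 and 1.3.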

Compound 4, distribution coefficient: 1
Estimate against measurement, compound 4: no gap at the digits printed, and the stated range covers the measured number.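

In this assay, methoxy in place of hydrogen on a saturated ring carbon gave a step of a number 0.30 log units lower from compound 2 to compound 4 (within the scatter) and, on the other core, a step of a number 0.30 log units lower from compound 3 to compound 1 (within the scatter), so the change carried across these two cores with a step of the same size. Each step lies within the scatter, however, so neither pair on its own establishes a real shift, and two matching pairs show agreement in this small set rather than a rule for the whole series. Nothing shown here gives a measured explanation for the agreement of the two steps.

From the compounds shown here alone, it remains open whether a hydroxy group, an amine or a longer chain such as ethoxy, placed on that saturated ring carbon of the cyclobutyl group in place of methoxy, would give matching steps on these two cores. Going by these compounds, it also remains open whether the step from cyclobutyl to 3-methoxycyclobutyl would keep its size on any third core.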